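The source may hold more compounds than are shown below. What is called first, only, known or untested is meant among the compounds shown, and "the series" means these compounds.

Compound 1 `CCCn1cnc2c1c(=O)n(C)c(=O)n2CCC`: 9400 nM
Compound 2 `CCCCn1cnc2c1c(=O)[nH]c(=O)n2CCC`: 12100 nM

Both compounds share one core and were tested in an assay on membranes from brain for displacement of a labelled ligand from adenosine receptor A1 (Cavia porcellus); a higher number here means a weaker inhibitor, a lower number a stronger inhibitor. In this assay compound 1 gives 9400 nM, and compound 2 gives 12100 nM; the two numbers sit within the usual scatter of each other, so neither can be called the stronger binder. Compound 3 `CCCCn1cnc2c1c(=O)n(C)c(=O)n2CCC` has not yet been measured. It differs from compound 2 in one place: methyl in place of hydrogen on an aromatic nitrogen. Compound 1 carries the same methyl on its own aromatic nitrogen, and compound 1 and compound 2 give numbers that are practically the same, so the methyl is not expected to change much. In this assay the expected step is a 1.5-fold lower number from compound 2 to compound 3 (0.18 log units; within the scatter), that is, at most a small shift toward a lower number. Compound 3 is therefore expected to give about 8000 nM, with a likely range from 3000 nM to 20000 nM.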

Compound 3, inhibition constant: 7300 nM
Beside the measured number, compound 3's estimate is 1.1-fold (0.04 log units) above it, and the stated range covers the measured number.
By their numbers in this assay, from the lowest: compounds 3, 1 and 2 (each within the scatter of the next).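

In this assay the aromatic nitrogen takes a methyl in place of hydrogen with a 1.7-fold lower number from compound 2 to compound 3 (0.22 log units; within the scatter) as the result, so on this shared core the two groups cannot be told apart at this position. The other step, methyl in place of hydrogen on a saturated chain carbon, three bonds along the chain from an aromatic nitrogen, gives a 1.3-fold lower number from compound 1 to compound 3 (0.11 log units; within the scatter) and so also leaves no readable difference. Nothing measured here bears on why either step is this small.

As far as these compounds go, what a bigger group on this nitrogen, such as a benzyl group or a chain ending in an amine, would do in this assay remains open. So does whether a much longer chain at the site that differs between compound 1 and compound 3 would still stay within the scatter.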